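The source may hold more compounds than are shown below. What is called first, only, known or untested is meant among the compounds shown, and "the series" means these compounds.

In a functional assay on K562 cells (Homo sapiens) for inhibition, read by sulforhodamine B assay, with a stated time of 48 h (on this read-out lower numbers stand for stronger inhibition of growth and higher numbers for weaker inhibition of growth), compound 1 (`S=C(N/N=C/c1cccs1)Nc1ccc(Cl)cc1`) gives 2000 nM, while compound 2 (`S=C(N/N=C/c1cccs1)Nc1cccnc1`) gives 16400 nM. Compound 1 therefore holds the lower of the two numbers, and the gap between them lies beyond the usual scatter of repeat measurements. Compound 3 (`S=C(N/N=C/c1cccs1)Nc1ccc(Br)cc1`) has not yet been tested in this assay. It keeps the core of compound 1 and alters a single spot: bromo in place of chloro on an aromatic carbon. Among the measured compounds shown here, no measured pair here shows this swap, so the direction of any change cannot be read from the data. Taking compound 1 at 2000 nM as the anchor, no step beyond the scatter is expected in this assay. The estimated move is a 1.1-fold lower number from compound 1 to compound 3 (0.02 log units; within the scatter). For compound 3 the expected value is 1900 nM, with an estimated range of 900 nM to 4200 nM.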

Compound 3, concentration for 50% growth inhibition: > 100000 nM
Compound 3: only a limit was reported; the forecaster's own chance of this, stated with the estimate: 2%; middle value at least 52-fold (1.72 log units) away from the limit.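

In this assay, replacing chloro with bromo on the aromatic carbon para to a large group gives an at least 50-fold higher number from compound 1 to compound 3 (1.69 log units; beyond the scatter). Compound 3 gives no number here, only a limit of the assay: the limit of > 100000 nM in this assay, at which 1 of the 3 values shown sits. Compound 1 and compound 2 differ in more than one place, so they could not show what this pair does: with the rest of the molecule unchanged, exchanging one halogen for another at this single position, with no ring, hydrogen-bond donor, hydrogen-bond acceptor or net charge added, can separate a compound with a measured value from one that reaches this limit.

These compounds do not show why the swap has such a large effect. They also leave open how growth inhibition would respond to a fluoro, methyl or methoxy group at the same position.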